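From isopropyl to propyl on an amine nitrogen

A few compounds are considered here, and "the series" means these few. Any claim that something is new, unique, unknown or untested is made for them only; others in the source may bear on it.

Compounds measured in an ADME assay on HepG2 cells (Homo sapiens) for cytotoxicity, read by CellTiter-Glo and resazurin assay, with a stated time of 72 h; a higher number here means that more compound is needed for the effect, a lower number that less compound is needed:
Compound 1 `CCOC(=O)CCCCCOc1cccc(CN(C(=O)c2ccc(Br)cc2)C(C)C)c1`: > 26000 nM
Compound 2 `CCOC(=O)CCCCCOc1cccc(CNC(C)C)c1`: > 26000 nM

In this assay compound 2 gives > 26000 nM, which is a limit and not a number. The measured set offers no numerical value against which to place it: the limit of > 26000 nM in this assay, at which 2 of the 2 values shown sit.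

Compound 3 `CCCNCc1cccc(OCCCCCC(=O)OCC)c1` has not yet been measured. It differs from compound 2 by a single change, (propyl in place of isopropyl on an amine nitrogen), with propyl in place of isopropyl on an amine nitrogen.

For the measured compounds named here, only one measured step bears on this comparison, and it involves a different change at the same nitrogen: a step that the two limits leave unreadable from compound 1 to compound 2. Its size cannot be read, so it provides no measured size to carry over. Compound 2 at > 26000 nM therefore remains the only anchor, and no shift beyond the usual scatter is expected in this assay, in either direction.

The step expected is a step that the limit leaves unreadable from compound 2 to compound 3, and a report of only a limit again seems likely. The estimate for compound 3 is 30000 nM, with an expected range from 15000 nM to 60000 nM.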

Compound 3, half-maximal effective concentration: > 26000 nM
Compound 3: only a limit was reported (the forecaster's own chance of this, stated with the estimate: 85%); the middle value is on the limit's open side.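

In this assay, no step can be read from compound 2 to compound 3, because each gives only a limit and not a number: the limit of > 26000 nM in this assay, at which 3 of the 3 values shown sit.

The compounds shown leave open whether any change at the amine nitrogen, or elsewhere on the shared core, would give a measurable value in this assay.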